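The compounds below may be only part of what the source reports. "The series", "measured", "known", "first", "only" and "open" are said of these compounds alone.

Compound 1 `CCCCCc1cc(C)c(C(=O)N=C(N)N)cc1S(C)(=O)=O` — 27 nM
Compound 2 `Cc1cc(-c2ccco2)c(S(C)(=O)=O)cc1C(=O)N=C(N)N` — 16 nM

For the measured compounds named here, in a functional assay for inhibition of sodium/hydrogen exchanger (Oryctolagus cuniculus) (on this read-out higher numbers stand for weaker inhibition and lower numbers for stronger inhibition), compound 2 stands alongside compound 1, the only other compound measured, and the two numbers lie within the usual scatter of one another: a 1.7-fold lower number from compound 1 to compound 2 (0.23 log units; within the scatter). Compound 3 `CCSc1cc(C)c(C(=O)N=C(N)N)cc1S(C)(=O)=O` has not been measured in this assay. It differs from compound 2 in one place: ethylsulfanyl in place of furan-2-yl on an aromatic carbon. Going by the values given here, the single measured step that bears on this position is the exchange of pentyl for furan-2-yl, which gave a 1.7-fold lower number from compound 1 to compound 2 (0.23 log units; within the scatter) and so showed no change beyond the scatter. Since a chain and a ring at this position gave much the same number, a shorter chain there is expected to do likewise, with no shift beyond the scatter, so that the estimated step is a 1.6-fold higher number from compound 2 to compound 3 (0.19 log units; within the scatter). Compound 3 is therefore expected to give about 25 nM in this assay, most likely between 10 nM and 70 nM.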

Compound 3, half-maximal inhibitory concentration: 5.9 nM
Compound 3: the middle estimate sits 4.2-fold (0.63 log units) above what was measured, outside the stated range (below it).
By their numbers in this assay, from the lowest: compound 3; then compounds 2 and 1 (each within the scatter of the next).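

In this assay, this position turns out to respond to the choice of group: ethylsulfanyl gives a 2.7-fold lower number from compound 2 to compound 3 (0.43 log units; beyond the scatter) and a 4.6-fold lower number from compound 1 to compound 3 (0.66 log units; beyond the scatter), both modest but beyond the scatter, whereas the earlier exchange of pentyl for furan-2-yl stayed within it. The lower number goes with ethylsulfanyl alone among the three groups, so a chain as such does not account for it, as pentyl shows, and neither a chain nor a ring separated the two earlier compounds. Nothing available explains this shift.

The compounds shown leave open whether the lower number follows the sulfur atom or the shorter chain, as ethylsulfanyl differs from pentyl in both. An ethoxy or a propyl group here would separate the two, and methylsulfanyl or a longer alkylsulfanyl chain would show how far the number follows chain length when sulfur is present.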